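Swapping Methoxy for Ethylamino on a Carbonyl Carbon

The compounds below may be only part of what the source reports. "The series", "measured", "known", "first", "only" and "open" are said of these compounds alone.

In an ADME assay on Jurkat cells (Homo sapiens) for cytotoxicity, read by MTT assay, with a stated time of 72 h (a lower number here means a stronger inhibitor, a higher number a weaker inhibitor), compound 1 (`COC(=O)c1ccc(Oc2ccc3c(c2)B(O)OC3)cn1`) reads > 100000 nM as a limit of the assay and not a number. For the measured compounds named here, compound 2 (`COC(=O)c1cnc(Oc2ccc3c(c2)B(O)OC3)cn1`) gives 7590 nM here, the only true number so far, so it cannot yet be placed in a series of measured values. Compound 3 (`CCNC(=O)c1cnc(Oc2ccc3c(c2)B(O)OC3)cn1`) keeps the shared core but has ethylamino in place of methoxy on a carbonyl carbon, and ethylamino in place of methoxy on a carbonyl carbon sets out that difference. Going by the values given here, no measured pair shows this change, so any expectation is loose. A moderate move toward weaker inhibition, meaning a higher number in this assay than compound 2 shows at 7590 nM seems most likely. The expected change is a 2.6-fold higher number from compound 2 to compound 3 (0.42 log units; beyond the scatter) in size, an estimate only. For compound 3 the estimated value is 20000 nM with an expected range from 5000 nM to 80000 nM as its likely span.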

Compound 3, half-maximal inhibitory concentration: 79900 nM
Compound 3: middle estimate off by 4.0-fold (0.60 log units), on the low side, and the stated range covers the measured number.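

In this assay, for the compounds shown here, this is the first step between two measured compounds that differ in one place: an 11-fold higher number from compound 2 to compound 3 (1.02 log units; beyond the scatter). Exchanging methoxycarbonyl for ethylcarbamoyl, with the rest of the structure unchanged, is therefore enough on its own to move the reading well beyond the scatter, so this position clearly matters to the result. Compound 3 gives 79900 nM, which is a true number. A further rise might not be readable as a true number, as with compound 1: the limit of > 100000 nM in this assay, at which 1 of the 3 values shown sits.

A single pair cannot separate the loss of methoxy from the gain of ethylamino, and it does not explain why the reading moves. Methylamino, a longer chain on the nitrogen or a carboxylic acid at this carbonyl carbon would help show whether the step follows the chain or the amide itself.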